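Bromo on the thiophen-2-yl group of compound 3

This account rests on a few compounds, and the source may have more. Where it says the series, first, only, none or still open, it means among the compounds named here.

Measured so far in a functional assay on HeLa cells (Homo sapiens) for inhibition, read by sulforhodamine B assay, with a stated time of 74 h (on this read-out lower numbers stand for stronger inhibition and higher numbers for weaker inhibition), for three compounds
Compound 1 `O=C1C=CC2(C=C1)OCC(=O)N2S(=O)(=O)c1ccccc1` gives > 10000 nM as a limit
Compound 2 `O=C1C=CC2(C=C1)OCC(=O)N2S(=O)(=O)c1ccc(Cl)cc1` gives > 10000 nM as a limit
Compound 3 `O=C1C=CC2(C=C1)OCC(=O)N2S(=O)(=O)c1cccs1` gives 3420 nM as a number

Compound 3 alone has a true number, and its steps from the other two lie beyond the scatter. Those two rest on the limit of > 10000 nM in this assay, at which 2 of the 3 values shown sit, and cannot be ranked. Compound 4 `O=C1C=CC2(C=C1)OCC(=O)N2S(=O)(=O)c1ccc(Br)s1` carries bromo in place of hydrogen on an aromatic carbon next to the ring sulfur, a change counted as bromo in place of hydrogen on an aromatic carbon on the thiophen-2-yl group. Among the compounds with values here, the nearest precedent, chloro in place of hydrogen, is a step that the two limits leave unreadable from compound 1 to compound 2 and gives no size. The ring swaps, an at least 2.9-fold lower number from compound 1 to compound 3 (0.46 log units; beyond the scatter) and an at least 2.9-fold lower number from compound 2 to compound 3 (0.46 log units; beyond the scatter) as measured, concern a different change and only loosely bear on it. A small step towards lower numbers is therefore expected in this assay with little confidence, and it may stay within the scatter. The expected change is a 1.4-fold lower number from compound 3 to compound 4 (0.14 log units; within the scatter) on this thin evidence. The estimate for compound 4 is 2500 nM as a central value, with an expected range from 700 nM to 9000 nM in this read-out.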

Compound 4, half-maximal inhibitory concentration: 30 nM
The estimate for compound 4 lay 83-fold (1.92 log units) above the measured number, and the stated range ends above it.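

In this assay a bromo on the aromatic carbon next to the ring sulfur gives a 110-fold lower number from compound 3 to compound 4 (2.06 log units; beyond the scatter) on its own, so this position of the thiophen-2-yl group responds strongly to a change of one heavy atom. Within the data shown here, the earlier chloro step could not be read, which makes this the first halogen step with a readable size. Set against 4-chlorophenyl and phenyl, 5-bromothiophen-2-yl gives an at least 330-fold lower number from compound 2 to compound 4 (2.52 log units; beyond the scatter) and an at least 330-fold lower number from compound 1 to compound 4 (2.52 log units; beyond the scatter) and both sizes remain lower bounds, because each starts from a limit: the limit of > 10000 nM in this assay, at which 2 of the 4 values shown sit.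

From the compounds shown here alone, what chloro, methyl or an amine on this same carbon would give stays open.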